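From compound 2 to compound 3: a pyridin-2-yl swap

This account rests on a few compounds, and the source may have more. Where it says the series, first, only, none or still open, it means among the compounds named here.

Measured so far in an ADME assay on Vero cells (Chlorocebus sabaeus) for cytotoxicity, read by MTT assay, with a stated time of 72 h (a lower number here means that less compound is tolerated, a higher number that more compound is tolerated), for the series:
compound 1 `CCOc1ccc(/C=C/C(=O)c2ccc3c(c2O)C=CC(C)(C)O3)cc1` gives 215000 nM as its result
compound 2 `CC1(C)C=Cc2c(ccc(C(=O)/C=C/c3ccc(Br)cc3)c2O)O1` gives "not determined" (no result reported) as its result

Compound 2 has no number to stand on: in this assay compound 2 is recorded as "not determined" (no result reported) and so offers no starting value for the step that follows. The only measured reference in the series is compound 1 (215000 nM), which shares its core with the other two compounds.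

Compound 3 `CC1(C)C=Cc2c(ccc(C(=O)/C=C/c3ccccn3)c2O)O1` is the next to be read. The change pyridin-2-yl in place of 4-bromophenyl on a double-bonded chain carbon bound to a double-bonded chain carbon puts pyridin-2-yl in place of 4-bromophenyl on a double-bonded chain carbon bound to a double-bonded chain carbon. Within the data shown here, no measured pair shows what this change does, and the data offer no direct comparison for it. The step expected in this assay is therefore none beyond the usual scatter, taking compound 1 at 215000 nM as the anchor, with a slight lean towards less compound being tolerated. The value estimated for compound 3 is 150000 nM (expected range 50000 nM to 400000 nM).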

Compound 3, half-maximal cytotoxic concentration: 20500 nM
For compound 3 the middle estimate is 7.3-fold (0.86 log units) above the measured one; measured number below the stated range.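

No new step can be read from compound 2 to compound 3 in this assay: compound 2 offers no number, so compound 3, at 20500 nM, has no partner for comparison. Nothing shown bears on the cause of this value. The compounds shown leave open what pyridin-2-yl in place of 4-bromophenyl does in this assay.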